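The source may hold more compounds than are shown below. What is called first, only, known or untested is meant among the compounds shown, and "the series" means these compounds.

In a functional assay on NCI-H630 cells (Homo sapiens) for cytotoxicity, read by sulforhodamine B assay, with a stated time of 5 days (on this read-out higher numbers stand for weaker inhibition and lower numbers for stronger inhibition), compound 1 `O=C(CCCCCCCc1ccccc1)CC(=O)N[C@H]1CCOC1=O` gives 10000 nM and compound 2 `O=C(CCCCCCCCCc1ccccc1)CC(=O)N[C@H]1CCOC1=O` gives 13000 nM with the two values inside the usual scatter of each other. Compound 3 `O=C(CCCCCCCCc1ccccc1)CC(=O)N[C@H]1CCOC1=O` comes from compound 2 by one change (phenyl in place of benzyl on a saturated chain carbon, eight bonds along the chain from a carbonyl carbon) described as phenyl in place of benzyl on a saturated chain carbon, eight bonds along the chain from a carbonyl carbon. Going by the values given here, the only measured step of this kind is a 1.3-fold higher number from compound 1 to compound 2 (0.11 log units; within the scatter) and it shortens or lengthens the same chain. The expected step is a 1.2-fold lower number from compound 2 to compound 3 (0.07 log units; within the scatter) and so no shift beyond the scatter is expected in this assay here. Compound 3 is estimated at 11000 nM with an expected range from 6500 nM to 19000 nM for this measurement.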

Compound 3, half-maximal inhibitory concentration: 10000 nM
Estimate against measurement, compound 3: 1.1-fold (0.04 log units) above, within the range that was stated.
By their numbers in this assay, from the lowest: compounds 1, 3 and 2 (each within the scatter of the next).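

With a third chain length on the shared core, this assay shows a 1.3-fold lower number from compound 2 to compound 3 (0.11 log units; within the scatter) and no change at the digits printed from compound 1 to compound 3 (within the scatter) and so all three compounds lie within the scatter of each other. Where the earlier pair gave a single step, this position now gives two, and neither the change from benzyl to phenyl nor the change from phenyl to benzyl moves the number beyond the scatter. No measurement here offers an explanation for this. Still open, as far as these compounds go, is whether a much shorter chain or a much longer one would shift the number beyond the scatter. Also open, from the compounds shown here alone, is what an amine or a carboxylic acid in place of phenyl would do.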